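This account rests on a few compounds, and the source may have more. Where it says the series, first, only, none or still open, it means among the compounds named here.

Three compounds built on one shared core differ only in the group carried on the oxygen of the aromatic ring attached to the piperazine. Compound 1 `COc1ccccc1N1CCN(CCCNc2ncccc2C(=O)N(C)C)CC1` gives 20 nM in a functional assay on aorta for antagonist activity at Alpha-1D adrenergic receptor (Rattus norvegicus); a lower number here means tighter binding, a higher number weaker binding. Compound 2 `CN(C)C(=O)c1cccnc1NCCCN1CCN(c2ccccc2OC(F)(F)F)CC1` gives 100 nM in this assay, the change being a 5.0-fold higher number from compound 1 to compound 2 (0.70 log units; beyond the scatter). Compound 3 `CN(C)C(=O)c1cccnc1NCCCN1CCN(c2ccccc2OCC2CC2)CC1` gives 10 nM in this assay; it is reached by a 2.0-fold lower number from compound 1 to compound 3 (0.30 log units; within the scatter) and by a 10-fold lower number from compound 2 to compound 3 (1.00 log units; beyond the scatter). Compound 3 therefore holds the lowest of the three numbers, although its gap to compound 1 lies within the scatter, so the two cannot be ranked against each other.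

Compound 4 `CN(C)C(=O)c1cccnc1NCCCN1CCN(c2ccccc2-c2ncco2)CC1` goes further than any measured step, replacing the whole oxygen-linked group with a ring bound straight to the aromatic carbon: 1,3-oxazol-2-yl in place of cyclopropylmethoxy on an aromatic carbon. Going by the values given here, no measured step makes a change of this kind, so the three steps only show how widely this position can swing, from a modest loss in a 5.0-fold higher number from compound 1 to compound 2 (0.70 log units; beyond the scatter) to a modest gain in a 10-fold lower number from compound 2 to compound 3 (1.00 log units; beyond the scatter). Given that span, compound 4 is expected to give about 30 nM in this assay, somewhere between 8 nM and 120 nM. The expected step is a 3.0-fold higher number from compound 3 to compound 4 (0.48 log units; beyond the scatter), a modest rise in the number that may still fall within the scatter.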

Compound 4, dissociation constant: 25.1 nM
Compound 4: the middle estimate sits 1.2-fold (0.08 log units) above what was measured; low and high end bracket the measured number.
By their numbers in this assay, from the lowest: compounds 3, 1 and 4 (each within the scatter of the next, the first and the last beyond it); then compound 2.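

Bound straight to the aromatic carbon with no oxygen link, the 1,3-oxazol-2-yl group still performs in this assay much as methoxy does, with a 1.3-fold higher number from compound 1 to compound 4 (0.10 log units; within the scatter), so these two cannot be ranked. The same ring gives different outcomes depending on the group it replaces: against cyclopropylmethoxy, which has the same count of heavy atoms, there is a 2.5-fold higher number from compound 3 to compound 4 (0.40 log units; beyond the scatter), while against trifluoromethoxy there is a 4.0-fold lower number from compound 2 to compound 4 (0.60 log units; beyond the scatter). Going by these compounds alone, the position therefore accepts an aromatic ring as well as oxygen-linked groups, and trifluoromethoxy in compound 2 is now the only group whose number lies beyond the scatter from all three others.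

No measurement shown here explains these differences between the groups. On these data alone, it remains open whether a plain phenyl ring, a 1,3-thiazol-2-yl ring or an amine on the same aromatic carbon would fall near compound 4, and so whether the ring's nitrogen and oxygen matter at all.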